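This account rests on a few compounds, and the source may have more. Where it says the series, first, only, none or still open, it means among the compounds named here.

Compound 1 `O=C(Nc1cc(Sc2ncnc3nc[nH]c23)c(O)c2ccccc12)c1ccc([N+](=O)[O-])cc1`: > 100000 nM
Compound 2 `O=C(Nc1cc(Sc2ncn[nH]2)c(O)c2ccccc12)c1ccc2ccccc2c1`: 45100 nM

In a functional assay on MDA-MB-231 cells (Homo sapiens) for antiproliferative activity, read by MTT assay, with a stated time of 48 h (on this read-out higher numbers stand for weaker inhibition and lower numbers for stronger inhibition), compound 1 gives only a limit, > 100000 nM, with no number reported. Compound 2 gives 45100 nM in this assay, the only number shown among the two values. Compound 3 `O=C(Nc1cc(Sc2ncn[nH]2)c(O)c2ccccc12)c1ccc([N+](=O)[O-])cc1` differs from compound 2 by 4-nitrophenyl in place of naphthalen-2-yl on a carbonyl carbon. No step between measured compounds is shown. With compound 1 sitting at the limit of > 100000 nM in this assay, at which 1 of the 2 values shown sits, a move toward weaker inhibition is expected, so from compound 2 to compound 3 a step of a 2.2-fold higher number from compound 2 to compound 3 (0.35 log units; beyond the scatter) is expected. Compound 3 is therefore estimated at 100000 nM, with a range from 40000 nM to 300000 nM.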

Compound 3, half-maximal inhibitory concentration: > 100000 nM
Compound 3 was reported as a limit; the forecaster's own chance of this, stated with the estimate: 55%; the middle value sits exactly at the limit.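

In this assay, the group on the carbonyl carbon matters with the rest of the molecule held fixed: 4-nitrophenyl in place of naphthalen-2-yl gives an at least 2.2-fold higher number from compound 2 to compound 3 (0.34 log units; beyond the scatter). From the compounds shown here alone, compound 3 gives only a limit, > 100000 nM, so the full size of this step stays unknown. The step from compound 1 to compound 3, a change on the sulfur, cannot be read, and both compounds stand at one limit: the limit of > 100000 nM in this assay, at which 2 of the 3 values shown sit.

Going by these compounds, whether an unsubstituted phenyl or a 4-aminophenyl on the carbonyl carbon would keep the number of compound 2 stays open. So does the effect of the larger group on the sulfur in compound 1 when naphthalen-2-yl sits on the carbonyl carbon.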